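The source may report more compounds than this note shows. Statements on the series, on what has been measured and on what is new or still open speak of the compounds shown alone.

Going by the values given here, the account starts from compound 1 `Cc1ccc(C)c(-c2nc(CN3CCC(C(=O)NCCCN4C[C@H](C)C[C@H](C)C4)CC3)c(C)o2)c1`, which in a physicochemical assay for solubility, in phosphate buffer, measured as kinetic solubility, at pH 7.4 (a lower number here means a less soluble compound, a higher number a more soluble compound), gives 56.1 ug/mL, the only actual number available so far. Among the compounds with values here, its one companion is compound 2 `Cc1ccccc1-c1nc(CN2CCC(C(=O)NCCCN3CCC(C(C)C)CC3)CC2)c(C)o1`, which reads > 71 ug/mL in this assay. That reading is a limit of the assay and not a number, so compound 1 can be placed only against that limit and not against a second measured value.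

The next compound is compound 3 `Cc1oc(-c2ccc(Cl)cc2)nc1CN1CCC(C(=O)NCCCN2C[C@H](C)C[C@H](C)C2)CC1`, which keeps the rest of compound 1 and alters a single group: 4-chlorophenyl in place of 2,5-dimethylphenyl on an aromatic carbon. In words, 4-chlorophenyl stands in place of 2,5-dimethylphenyl on an aromatic carbon. Within the data shown here, no measured pair here shows what a change of this kind does, so the expectation is anchored on compound 1 and its 56.1 ug/mL. No change beyond the usual scatter is expected, with only a slight lean towards a less soluble compound, and the estimated move is a 1.3-fold lower number from compound 1 to compound 3 (0.13 log units; within the scatter). For compound 3 the estimated value in this assay is 42 ug/mL, with an expected range of 18 ug/mL to 80 ug/mL.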

Compound 3, solubility: > 72 ug/mL
Compound 3 ended at the assay's limit; the forecaster's own chance of this, stated with the estimate: 15%; middle value at least 1.7-fold (0.23 log units) from the limit.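

Going by these compounds alone, at the aromatic carbon of the five-membered aromatic ring, this is the first pair in which only the aryl group differs, and in this assay putting 4-chlorophenyl in place of 2,5-dimethylphenyl gives an at least 1.2-fold higher number from compound 1 to compound 3 (0.10 log units; that floor lies within the scatter). The reading for compound 3 is a limit of the assay and not a number, so the pair fixes only a floor for the step and not its size: the limit of > 72 ug/mL in this assay, at which 1 of the 3 values shown sits. What this adds is a direction, since the change, which removes both methyl groups and brings in a chlorine, did not give a lower number at this position, although the floor itself does not go beyond the usual scatter.

On these data alone, how far compound 3 actually lies past its limit stays unknown, and with a single exchange the share of the chlorine cannot be separated from the share of the two lost methyl groups. Neither an unsubstituted phenyl nor a 4-methylphenyl at this place is among the compounds shown, nor is a group carrying a carboxylic acid or an amine, so what such groups would do here remains open.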